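A Second Methyl on the Aryl Thioether

A few compounds are considered here, and "the series" means these few. Any claim that something is new, unique, unknown or untested is made for them only; others in the source may bear on it.

Compound 3 `Cc1cccc(Sc2c[nH]c3ccc(Cl)cc23)c1` gives 100000 nM in an assay on isolated protein for inhibition of Indoleamine 2,3-dioxygenase 1 (Homo sapiens), read by HPLC, with a stated time of 60 min, in the presence of a further agent that is not named here (a higher number here means a weaker inhibitor, a lower number a stronger inhibitor), and stands highest of the two compounds with a number in that assay; compound 2 `COc1cccc(Sc2c[nH]c3ccc(Cl)cc23)c1` gives 21000 nM, and the difference is a 4.8-fold higher number from compound 2 to compound 3 (0.68 log units; beyond the scatter). Compound 1 `Clc1ccc2[nH]cc(Sc3ccccc3)c2c1` returns only a limit in this assay, > 200000 nM. Compound 4 `Cc1cc(C)cc(Sc2c[nH]c3ccc(Cl)cc23)c1` differs from compound 3 by methyl in place of hydrogen on an aromatic carbon. Within the data shown here, the one measured step of the same kind is an at least 2.0-fold lower number from compound 1 to compound 3 (0.30 log units; that floor lies within the scatter); that step rests on (the limit of > 200000 nM in this assay, at which 1 of the 3 values shown sits), so only its floor is known. The other step, an at least 9.5-fold lower number from compound 1 to compound 2 (0.97 log units; beyond the scatter), concerns methoxy rather than methyl and bears on the present change only loosely. On this basis the writer expects a small lowering in this assay or none beyond the scatter, a 1.7-fold lower number from compound 3 to compound 4 (0.22 log units; within the scatter). Compound 4 is therefore estimated at 60000 nM in this assay, with a range from 20000 nM to 200000 nM.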

Compound 4, half-maximal inhibitory concentration: 20000 nM
For compound 4 the middle estimate is 3.0-fold (0.48 log units) above the measured one, and the stated range covers the measured number.
By their numbers in this assay, from the lowest: compounds 4 and 2 (each within the scatter of the next); then compound 3. At a limit, above all of these: compound 1.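

In this assay, the second methyl gives a step that can be read in full: a 5.0-fold lower number from compound 3 to compound 4 (0.70 log units; beyond the scatter). This shows that a methyl in place of hydrogen on an aromatic carbon, here meta to a methyl group and meta to a large group, can by itself move the number beyond the scatter. From the compounds shown here alone, the earlier step of the same kind gave only a floor, an at least 2.0-fold lower number from compound 1 to compound 3 (0.30 log units; that floor lies within the scatter), and so its true size remains unknown: the limit of > 200000 nM in this assay, at which 1 of the 4 values shown sits.

The compounds shown leave open whether the two methyl groups contribute equally, as only the second has a step of known size. They also leave open how this position would respond to an ethyl group, an amine or a carboxylic acid in place of the new methyl.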